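A few compounds are considered here, and "the series" means these few. Any claim that something is new, unique, unknown or untested is made for them only; others in the source may bear on it.

In an ADME assay on microsomes from liver (Mus musculus) for metabolic stability, read by LC-MS, with NADPH named in the record, with a stated time of 60 min, tested at 1 uM, in the absence of a further agent (a higher number here means that more of the compound is left, a lower number that less of the compound is left), compound 1 (`CC(=O)N[C@@H]1CCN(c2cc(C)nn3c(-c4ccc(C(F)(F)F)cc4)c(C)nc23)C1`) gives > 95% and this is a limit of the assay. Compound 2 (`COc1ccc(-c2c(C)nc3c(N4CC[C@@H](NC(C)=O)C4)cc(Cl)nn23)cc1OC`) gives > 95% in this assay and this too is a limit. Compound 3 (`COc1ccc(-c2c(C)nc3c(N4CC[C@@H](NC(=O)c5ccccc5)C4)cc(C)nn23)cc1OC`) gives > 95% in this assay and this is again a limit, so its standing has no exact number. Taken together, the measurements show the limit of > 95% in this assay, at which 3 of the 3 values shown sit, and no measured step links any two of these compounds.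

Compound 4 (`COc1ccc(-c2c(C)nc3c(N4CC[C@@H](NC(=O)OCc5ccccc5)C4)cc(C)nn23)cc1OC`) differs from compound 3 by having benzyloxy in place of phenyl on a carbonyl carbon and the same difference reads as benzamido to (benzyloxycarbonyl)amino. Among the compounds with values here, with no measured step to guide the estimate, only a modest fall is expected in this assay and the estimated step of a number at least 7 percentage points lower from compound 3 to compound 4 (that floor lies within the scatter) may not clearly exceed the usual scatter. A reading at the limit would therefore also fit this expectation. For compound 4 the estimate is 88% with an expected range from 60% to 100%.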

Compound 4, percent of the compound remaining: > 95%
Compound 4 ended at the assay's limit (the forecaster's own chance of this, stated with the estimate: 40%); middle value at least 7 percentage points away from the limit.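

Compound 4 gives > 95% in this assay, and this is a limit of the assay. Compound 3 also stands at a limit, so no step can be read from compound 3 to compound 4. The compounds shown leave open how they rank against one another, because none has an exact number: the limit of > 95% in this assay, at which 4 of the 4 values shown sit.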